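A few compounds are considered here, and "the series" means these few. Any claim that something is new, unique, unknown or untested is made for them only; others in the source may bear on it.

In an assay on brain for displacement of a labelled ligand from 5-hydroxytryptamine receptor 4 (Cavia porcellus), with a stated time of 30 min, in the presence of a further agent that is not named here (on this read-out lower numbers stand for stronger inhibition and higher numbers for weaker inhibition), compound 2 `COc1cc(N)c(Cl)cc1C(=O)CCC1CCN(CCNS(=O)(=O)c2ccc(N)c(Br)c2)CC1` stands at 5.3 nM, and compound 1 `COc1cc(N)c(Cl)cc1C(=O)CCC1CCN(CCNS(=O)(=O)c2ccc3c(c2)NC(=O)CO3)CC1` stands at 6.2 nM, within the scatter of it. Among the measured compounds shown here, the only measured step reads a 1.2-fold lower number from compound 1 to compound 2 (0.07 log units; within the scatter), even though it exchanged the whole group on the sulfonyl sulfur. Compound 3 `COc1cc(N)c(Cl)cc1C(=O)CCC1CCN(CCNS(=O)(=O)c2ccc(N)cc2)CC1` differs from compound 2 by hydrogen in place of bromo on an aromatic carbon. Since a far larger change on the same part left the number within the scatter, the step is expected to be a 1.9-fold higher number from compound 2 to compound 3 (0.28 log units; within the scatter). Compound 3 is therefore estimated at 10 nM, with a range from 3 nM to 35 nM.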

Compound 3, inhibition constant: 1.97 nM
Beside the measured number, compound 3's estimate is 5.1-fold (0.71 log units) above it, and the stated range ends above it.
By their numbers in this assay, from the lowest: compound 3; then compounds 2 and 1 (each within the scatter of the next).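

In this assay, taking away the bromo on the aromatic carbon ortho to an amino group gives a step beyond the scatter (a 2.7-fold lower number from compound 2 to compound 3 (0.43 log units; beyond the scatter)), so a single atom at this position moves the number, although the much larger exchange from compound 1 to compound 2 stayed within the scatter. The 4-aminophenyl group of compound 3 also separates from the group on compound 1 (a 3.1-fold lower number from compound 1 to compound 3 (0.50 log units; beyond the scatter)). No measured evidence accounts for either step. Open, going by these compounds, is how a fluoro, chloro or methyl group on this same carbon would compare with bromo and hydrogen.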